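This account rests on a few compounds, and the source may have more. Where it says the series, first, only, none or still open, it means among the compounds named here.

Measured so far:
compound 1 `CN1CCN(c2ccc(Nc3ncc4nc(Sc5ccccc5)n([C@H]5CC[C@H](O)CC5)c4n3)cc2)CC1` gives 42.6 nM
compound 2 `CN1CCN(c2ccc(Nc3ncc4nc(Sc5ccccc5)n(CC5CC5)c4n3)cc2)CC1` gives 660 nM

Both numbers come from a functional assay on HCC827 cells (Homo sapiens) for antiproliferative activity, read by MTT assay, with a stated time of 72 h; on this read-out lower numbers stand for stronger inhibition and higher numbers for weaker inhibition. Among the measured compounds shown here, compound 2 stands with the highest of the two numbers, and its only neighbour is compound 1: the step of a 15-fold higher number from compound 1 to compound 2 (1.19 log units; beyond the scatter) put cyclopropylmethyl in place of 4-hydroxycyclohexyl on an aromatic nitrogen. Compound 3 `CN1CCN(c2ccc(Nc3ncc4nc(Sc5ccccc5)n(C5CC5)c4n3)cc2)CC1` has not yet been measured. It differs from compound 2 in one place: cyclopropyl in place of cyclopropylmethyl on an aromatic nitrogen. For the measured compounds named here, the one measured step bears on this change only loosely, since it exchanged the whole group on that nitrogen, whereas the present change keeps the three-membered non-aromatic ring of carbon only and attaches it directly to the aromatic nitrogen. Nothing in the measured pair shows how much the chain that carries the ring matters. A small move in either direction is therefore expected, most likely within the scatter, with a slight lean toward a lower number: the step from compound 2 is expected to be a 1.3-fold lower number from compound 2 to compound 3 (0.12 log units; within the scatter). For compound 3 the estimated value in this assay is 500 nM, expected to fall between 150 nM and 1800 nM.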

Compound 3, half-maximal inhibitory concentration: 305 nM
Beside the measured number, compound 3's estimate is 1.6-fold (0.21 log units) above it; the range from low to high includes it.
By their numbers in this assay, from the lowest: compound 1; then compound 3; then compound 2.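

In this assay, this position responds even to a small edit, with a 2.2-fold lower number from compound 2 to compound 3 (0.34 log units; beyond the scatter) when the three-membered ring stays and only its link to the aromatic nitrogen goes, taking the group from 4 heavy atoms to 3. Attaching the ring directly closes only part of the gap to the 4-hydroxycyclohexyl group, as a 7.2-fold higher number from compound 1 to compound 3 (0.85 log units; beyond the scatter) still separates the two, so a shorter attachment alone does not match that group. No measurement shown here explains either change.

The compounds shown change the ring and the hydroxyl together when 4-hydroxycyclohexyl is exchanged, so they cannot say how much of the lower number in compound 1 goes with the larger ring and how much with the hydroxyl; a plain cyclohexyl group, or an amine in place of the hydroxyl, would bear on that. Going by these compounds, it also remains open whether a small open chain such as ethyl or isopropyl on the same nitrogen would behave like the ring-bearing groups.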